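The source may report more compounds than this note shows. Statements on the series, on what has been measured and on what is new or still open speak of the compounds shown alone.

Compound 1 `COc1ccc(Cn2cc(/C=N\NC(=O)c3c[nH]c4ccc(Br)cc34)c3ccc(F)cc32)cc1` and compound 2 `COc1ccc(Cn2cc(/C=N\NC(=O)c3c[nH]c4ccccc34)c3ccc(F)cc32)cc1` share one core and differ by hydrogen in place of bromo on an aromatic carbon. In a functional assay on LNCaP cells (Homo sapiens) for cytotoxicity (a lower number here means a stronger inhibitor, a higher number a weaker inhibitor), compound 1 gives only a limit of the assay, > 100000 nM. In this assay compound 2 likewise gives only a limit, > 100000 nM. The step is a step that the two limits leave unreadable from compound 1 to compound 2 because of the limit of > 100000 nM in this assay, at which 2 of the 3 values shown sit. Compound 3 `O=C(N/N=C\c1cn(Cc2ccc(Cl)cc2)c2ccc(Br)cc12)c1c[nH]c2ccccc12` has another core; the difference between the two cores is not broken down here. In this assay compound 3 gives 3700 nM. Compound 4 `O=C(N/N=C\c1cn(Cc2ccc(Cl)cc2)c2ccccc12)c1c[nH]c2ccccc12` is not yet measured and differs from compound 3 by hydrogen in place of bromo on an aromatic carbon, the same change as between compound 1 and compound 2, whose step gave no readable size. The step is expected to be a 2.2-fold higher number from compound 3 to compound 4 (0.33 log units; beyond the scatter), a small move toward a weaker inhibitor. The estimate for compound 4 in this assay is 8000 nM, between 2000 nM and 40000 nM, resting on compound 3 at 3700 nM.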

Compound 4, half-maximal inhibitory concentration: > 100000 nM
Compound 4: a limit, no number; the forecaster's own chance of this, stated with the estimate: 15%; middle value at least 12-fold (1.09 log units) from the limit.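

Compound 4 gives only a limit of the assay, > 100000 nM. On this core, hydrogen in place of bromo gives an at least 27-fold higher number from compound 3 to compound 4 (1.43 log units; beyond the scatter) in this assay, so losing the bromo here takes the series from a readable number to no readable number. This does not show that the change carries from one core to another, since the same change on the other core cannot be read and both of its compounds sit at the limit: the limit of > 100000 nM in this assay, at which 3 of the 4 values shown sit.

Going by these compounds, the full size of the new step stays open, as does any effect of the change on a core where both compounds give a readable number. Also open, on these data alone, is whether a nitrile or an amine on that aromatic carbon would give a readable number, as bromo does.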